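From Iodo to Amino on the Shared Core

A few compounds are considered here, and "the series" means these few. Any claim that something is new, unique, unknown or untested is made for them only; others in the source may bear on it.

Compound 1, `OCCOCn1cnc2c(O)ncnc21`: > 1000 ug/mL, a limit of the assay
Compound 2, `Nc1nc2c(nc(Cl)n2COCCO)c(=O)[nH]1`: 350 ug/mL
Compound 3, `Nc1nc2c(nc(I)n2COCCO)c(=O)[nH]1`: 39 ug/mL

In a functional assay on L1210 cells (Mus musculus) for inhibition (a higher number here means a weaker inhibitor, a lower number a stronger inhibitor), compound 1 reaches only the limit > 1000 ug/mL, which is a limit and not a number. Within the data shown here, of the two numbers, compound 3 has the lowest in this assay; its nearest neighbour is compound 2, separated by the one measured step, a 9.0-fold lower number from compound 2 to compound 3 (0.95 log units; beyond the scatter), which was iodo in place of chloro on an aromatic carbon. Compound 4, `Nc1nc2c(nc(N)n2COCCO)c(=O)[nH]1`, is not yet measured. It differs from compound 3 by amino in place of iodo on an aromatic carbon. Among the measured compounds shown here, no measured step concerns an amino group: the only step seen, a 9.0-fold lower number from compound 2 to compound 3 (0.95 log units; beyond the scatter), swapped one group for another, and nothing among the three compounds shows how an amino group behaves in this assay. With iodo giving the lowest number and chloro a clearly higher one, a step back toward a higher number seems the more likely outcome, though its size cannot be read from these data. Compound 4 is therefore expected to show a 5.1-fold higher number from compound 3 to compound 4 (0.71 log units; beyond the scatter) in this assay. The estimate for compound 4 is 200 ug/mL, with a range from 40 ug/mL to 1000 ug/mL, and a real chance that only a limit is reported.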

Compound 4, concentration for 50% inhibition: > 500 ug/mL
Compound 4 was reported as a limit (the forecaster's own chance of this, stated with the estimate: 25%); at least 2.5-fold (0.39 log units) between middle value and limit.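

Compound 4 adds a third group at the same position, the aromatic carbon between two ring nitrogen atoms, and it shows that the low number in this assay does not carry over to amino: an at least 12-fold higher number from compound 3 to compound 4 (1.10 log units; beyond the scatter). For compound 4 the assay gives only a limit and not a number: the limit of > 500 ug/mL in this assay, at which 1 of the 4 values shown sits. The comparison with chloro is less firm, since the step reads an at least 1.4-fold higher number from compound 2 to compound 4 (0.15 log units; that floor lies within the scatter), so amino and chloro cannot be put in order, and among these three groups only iodo stands clearly apart from both others.

The compounds shown leave open how far the true value of compound 4 lies from its limit, and they give no reason why iodo stands apart from chloro and amino at this position. On these data alone, whether the lower number belongs to iodo alone or extends to other groups on the same carbon, such as bromo, a methyl group or a longer chain, also remains unknown, as does the effect of replacing the (2-hydroxyethoxy)methyl group while iodo stays in place.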